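Series notes: removing the chloro from compound 2

This account rests on a few compounds, and the source may have more. Where it says the series, first, only, none or still open, it means among the compounds named here.

Compound 1 `O=C(CSC(=S)N[C@H]1CCOC1=O)Nc1ccccc1F` and compound 2 `O=C(CSC(=S)N[C@H]1CCOC1=O)Nc1cccc(Cl)c1` share one core and differ only in the aryl group on the amide-type nitrogen. In a functional assay on SMMC-7721 cells (Homo sapiens) for cytotoxicity, read by MTT assay, with a stated time of 72 h (on this read-out lower numbers stand for stronger inhibition and higher numbers for weaker inhibition), compound 1 gives only a limit, > 128000 nM. In this assay compound 2 likewise gives only a limit, > 128000 nM. The step that the two limits leave unreadable from compound 1 to compound 2 therefore cannot be read. Compound 2 thus stands at the limit of > 128000 nM in this assay, at which 2 of the 2 values shown sit, without a numeric value.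

Compound 3 `O=C(CSC(=S)N[C@H]1CCOC1=O)Nc1ccccc1` is obtained from compound 2 by hydrogen in place of chloro on an aromatic carbon, meta to a large group. Within the data shown here, no measured step bears on this change, and the one step recorded, a step that the two limits leave unreadable from compound 1 to compound 2, is unreadable, so neither direction nor size can be drawn from it. Compound 3 is therefore expected to remain at the limit in this assay, with an estimate of 160000 nM within 60000 nM to 450000 nM. The step that the limit leaves unreadable from compound 2 to compound 3 is accordingly expected to be no larger than scatter.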

Compound 3, half-maximal inhibitory concentration: > 128000 nM
Compound 3: a limit, no number; the forecaster's own chance of this, stated with the estimate: 80%; the middle value does not contradict the limit.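

No new step can be read among compound 1, compound 2 and compound 3, as each gives only a limit in this assay: the limit of > 128000 nM in this assay, at which 3 of the 3 values shown sit. The compounds shown leave open how these three rank against one another, and whether any change to the shared core would give a numeric value.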